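Removing the Aromatic Group from Compound 2

The compounds below may be only part of what the source reports. "The series", "measured", "known", "first", "only" and "open" are said of these compounds alone.

In a functional assay on MCF7 cells (Homo sapiens) for inhibition, read by MTT assay, with a stated time of 48 h (a higher number here means a weaker inhibitor, a lower number a stronger inhibitor), compound 1 `CCOC(=O)C1=C(N/C=N/c2ccccn2)Nc2[nH]nc(C)c2C1c1ccc(N(C)C)cc1` gives 37300 nM and compound 2 `CCOC(=O)C1=C(N/C=N/c2ccc(C)cc2)Nc2[nH]nc(C)c2C1c1ccc(N(C)C)cc1` gives 50500 nM so compound 2 stands level with compound 1 within the scatter. Among the compounds with values here, compound 3 `CCOC(=O)C1=C(N)Nc2[nH]nc(C)c2C1c1ccc(N(C)C)cc1` keeps the core of compound 2 and differs by a hydrogen atom in place of a group of 9 heavy atoms (8 carbon, 1 nitrogen; one six-membered aromatic ring of carbon only), on an amine nitrogen as its one structural change. Within the data shown here, only one measured step bears on this: a 1.4-fold higher number from compound 1 to compound 2 (0.13 log units; within the scatter) is an exchange of pyridin-2-yl for 4-methylphenyl on a double-bonded nitrogen and lies within the scatter. Among the measured compounds shown here, that step replaces one aromatic ring with another, whereas no measured compound lacks the group altogether, so the data give neither a size nor a direction for its removal. With nothing pointing either way, no step beyond the scatter is expected in this assay. The estimate stays close to compound 2 at 50500 nM with a wide margin on both sides. The estimated change is a 1.1-fold lower number from compound 2 to compound 3 (0.05 log units; within the scatter) on this reasoning. For compound 3 the expected value is 45000 nM with an estimated range from 15000 nM to 130000 nM as its likely span.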

Compound 3, half-maximal inhibitory concentration: 5060 nM
Beside the measured number, compound 3's estimate is 8.9-fold (0.95 log units) above it; measured number below the stated range.
By their numbers in this assay, from the lowest: compound 3; then compounds 1 and 2 (each within the scatter of the next).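

In this assay the amine nitrogen proves to be a place where the change counts: the earlier pair only exchanged one aromatic ring for another and stayed within the scatter, whereas taking the whole group away gives a 10-fold lower number from compound 2 to compound 3 (1.00 log units; beyond the scatter) and also a 7.4-fold lower number from compound 1 to compound 3 (0.87 log units; beyond the scatter) as a second reading of the same removal. Both steps lie beyond the scatter and run the same way, so compound 3, with a plain hydrogen on that nitrogen, is the strongest of the three, whichever of the two rings the group carries in the compound it is set against. No measurement at hand offers an explanation for this drop in the number on removing the group.

Going by these compounds, what stays open is whether the whole group has to go, or whether a small substituent such as a methyl or an acetyl on the same amine nitrogen would stand with compound 3 or with the two ring-bearing compounds. On these data alone, it is also open whether the same step would hold on a core carrying a carboxylic acid in place of the ethyl ester.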